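The compounds below may be only part of what the source reports. "The series", "measured", "known", "first", "only" and "open" are said of these compounds alone.

Working notes on the series.

Compound 1 `FC1(F)CCC(NCc2ccc(CN(C[C@H]3Cc4ccccc4CN3)[C@H]3CCCc4cccnc43)cc2)CC1` and compound 2 `c1ccc2c(c1)CN[C@@H](CN(Cc1ccc(CNC3CCOCC3)cc1)[C@H]1CCCc3cccnc31)C2` share one core; compound 3 `FC1(F)CCC(NC/C=C/CN(C[C@H]2Cc3ccccc3CN2)[C@H]2CCCc3cccnc32)CC1` and compound 4 `C(=C/CN(C[C@H]1Cc2ccccc2CN1)[C@H]1CCCc2cccnc21)\CNC1CCOCC1` share another. The difference between the two cores is not broken down here. In a functional assay on cells for antagonist activity at C-X-C chemokine receptor type 4 (Homo sapiens), read by fluorescence and calcium flux, with stated times of 25 min and 90 s (on this read-out lower numbers stand for stronger inhibition and higher numbers for weaker inhibition), compound 1 gives 143 nM. In this assay, among the measured compounds shown here, compound 2 gives 90.3 nM, and the step of a 1.6-fold lower number from compound 1 to compound 2 (0.20 log units; within the scatter) is the single change (oxan-4-yl in place of 4,4-difluorocyclohexyl on an amine nitrogen). In this assay compound 3 gives 82.1 nM, which stands within the scatter of both compound 1 and compound 2, so no order among the three is claimed.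

Compound 4 carries the same change as compound 2 does relative to compound 1: oxan-4-yl in place of 4,4-difluorocyclohexyl on an amine nitrogen. The place of the change is the same word for word in both pairs, an amine nitrogen whose other neighbours are a saturated chain carbon, so the change is the same, made on a different core. It occurs twice among the compounds shown, once measured and once not.

On that basis the expected step of a 1.5-fold lower number from compound 3 to compound 4 (0.17 log units; within the scatter) is set beside the earlier one, resting on compound 1 to compound 2 having given a 1.6-fold lower number from compound 1 to compound 2 (0.20 log units; within the scatter) in this assay; a step of that size lies within the scatter, so the estimate is essentially compound 3 with a modest downward lean. Compound 4 is thus expected to give about 55 nM in this assay, with 28 nM and 120 nM as the expected range, pending the measurement.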

Compound 4, half-maximal inhibitory concentration: 15.5 nM
For compound 4 the middle estimate is 3.5-fold (0.55 log units) above the measured one; measured number below the stated range.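

In this assay, oxan-4-yl in place of 4,4-difluorocyclohexyl on an amine nitrogen gives a 5.3-fold lower number from compound 3 to compound 4 (0.72 log units; beyond the scatter), so the size of the step does not carry over from one core to the other: the same change on two cores in this assay, a 1.6-fold lower number (0.20 log units; within the scatter) from compound 1 to compound 2 and a 5.3-fold lower number (0.72 log units; beyond the scatter) from compound 3 to compound 4, 3.3-fold (0.52 log units) apart, beyond the scatter of two such steps. Among the compounds shown here, the printed numbers fall in the same direction on both cores, but only the step on the core of compound 3 lies beyond the scatter, so a transfer of direction is suggested at most and is not established. This shows that, for these two pairs, the core on which the change is made matters to the size of the step; it does not show which part of the core difference is responsible, why the steps differ, or that the larger step would hold for any further core in the series.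

The compounds shown leave open whether the larger step on the core of compound 3 is particular to oxan-4-yl or would also appear with another group on the same amine nitrogen, such as a plain cyclohexyl or an open-chain amine. They also leave open how the step would behave on a core with a longer chain, which would help to show how far its size follows the core.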